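A few compounds are considered here, and "the series" means these few. Any claim that something is new, unique, unknown or untested is made for them only; others in the source may bear on it.

The series shares one core and varies only the aromatic group attached to it. Compound 1 `CN1CCC[C@H]1COc1cncc(-c2ccc(F)cc2)c1` gives 0.11 nM in an assay on membranes from brain for binding affinity to Neuronal acetylcholine receptor; alpha4/beta2 (Rattus norvegicus) (a higher number here means a weaker inhibitor, a lower number a stronger inhibitor), and compound 2 `CN1CCC[C@H]1COc1cncc(-c2ccc(Cl)cc2)c1` gives 0.082 nM; the step of a 1.3-fold lower number from compound 1 to compound 2 (0.13 log units; within the scatter) lies within the scatter. Compound 3 `CN1CCC[C@H]1COc1cncc(-c2cccnc2)c1` gives 0.27 nM, the highest of the three numbers, separated from both neighbours by steps beyond the scatter: a 2.5-fold higher number from compound 1 to compound 3 (0.39 log units; beyond the scatter) and a 3.3-fold higher number from compound 2 to compound 3 (0.52 log units; beyond the scatter).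

Compound 4 `CN1CCC[C@H]1COc1cncc(-c2ccco2)c1` carries the change (furan-2-yl in place of pyridin-3-yl on an aromatic carbon). Within the data shown here, no measured step swaps one heteroaryl for another, so the nearest guidance comes from the two exchanges of a substituted phenyl for pyridin-3-yl, each of which raised the number modestly. Those steps suggest that the aromatic group at this position moves the number by modest amounts rather than by large ones, and that a change away from the substituted phenyl groups tends upward. Compound 4 is therefore expected to show a modest step, a 1.9-fold higher number from compound 3 to compound 4 (0.27 log units; within the scatter), most likely upward, though the margin against no change beyond the scatter is thin. Compound 4 is estimated at 0.5 nM, with a range from 0.15 nM to 1.8 nM.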

Compound 4, inhibition constant: 0.19 nM
Estimate against measurement, compound 4: 2.6-fold (0.42 log units) above; the measured number falls inside the stated range.
By their numbers in this assay, from the lowest: compounds 2, 1, 4 and 3 (each within the scatter of the next, the first and the last beyond it).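

Furan-2-yl in place of pyridin-3-yl (a 1.4-fold lower number from compound 3 to compound 4 (0.15 log units; within the scatter)) is the first exchange of one heteroaryl for another at this position, and it shows that in this assay a five-membered aromatic ring with an oxygen can stand here in place of a six-membered one with a nitrogen without a step beyond the scatter. Compared with the substituted phenyl groups, compound 4 separates only from the 4-chlorophenyl compound (a 2.3-fold higher number from compound 2 to compound 4 (0.36 log units; beyond the scatter)) and not from the 4-fluorophenyl compound (a 1.7-fold higher number from compound 1 to compound 4 (0.24 log units; within the scatter)), whereas compound 3 lay beyond the scatter from both. The data offer no measurement that explains how these aromatic groups act at this position.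

From the compounds shown here alone, all four compounds carry a single aromatic ring on this carbon, so it remains open whether thiophen-2-yl or furan-3-yl would stay in the same narrow range. Going by these compounds, it is equally open whether a non-aromatic group, such as a primary amine, a carboxylic acid or a longer alkyl chain, would keep the number there or move it by much larger steps.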